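The source may hold more compounds than are shown below. What is called first, only, known or untested is meant among the compounds shown, and "the series" means these compounds.

Of the compounds shown here, two with the same core have been measured so far in a functional assay on a cell-free system (Platelet, plasma, Homo sapiens) for inhibition (on this read-out higher numbers stand for weaker inhibition and lower numbers for stronger inhibition), and differ in the chain on the ring nitrogen. Compound 1 (`O=C(O)CN1Cc2ccc(NC(=O)c3ccc4c(c3)CNCC4)cc2C1=O`) reads 120000 nM in this assay and compound 2 (`O=C(O)CCN1Cc2ccc(NC(=O)c3ccc4c(c3)CNCC4)cc2C1=O`) reads 1100 nM as the lower of the two numbers, which marks it as the stronger inhibitor. Among the measured compounds shown here, the one measured step reads a 110-fold lower number from compound 1 to compound 2 (2.04 log units; beyond the scatter) and comes with carboxymethyl in place of carboxy on a saturated chain carbon bound to an amide-type nitrogen in a ring. Compound 3 (`CC(CC(=O)O)N1Cc2ccc(NC(=O)c3ccc4c(c3)CNCC4)cc2C1=O`) is compound 2 with methyl in place of hydrogen on a saturated chain carbon bound to an amide-type nitrogen in a ring and a saturated chain carbon. For the measured compounds named here, no measured step adds a methyl, so the large step from compound 1 to compound 2 bears on this change only loosely, by showing that one edit to this chain can move the number far. Going by these compounds, a much smaller step is expected here, leaning slightly towards a higher number, though the direction stays open. The expected change is a 1.5-fold higher number from compound 2 to compound 3 (0.16 log units; within the scatter) at the middle of the estimate. For compound 3 the estimated value is 1600 nM in this assay (expected range 350 nM to 8000 nM).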

Compound 3, half-maximal inhibitory concentration: 86 nM
Beside the measured number, compound 3's estimate is 19-fold (1.27 log units) above it; the measured number lies below the stated range.
By their numbers in this assay, from the lowest: compound 3; then compound 2; then compound 1.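

In this assay, methyl in place of hydrogen on this saturated chain carbon gives a 13-fold lower number from compound 2 to compound 3 (1.11 log units; beyond the scatter), which shows that an edit adding only 1 heavy atom can shift the number well beyond the scatter at this position. The earlier compounds shown here showed a large shift only for carboxymethyl in place of carboxy, whereas the 1-(carboxymethyl)ethyl chain in place of carboxymethyl gives a 1400-fold lower number from compound 1 to compound 3 (3.14 log units; beyond the scatter), so both edits to this chain lower the number and compound 3 now stands lowest of the three, with its steps to the other two beyond the scatter. Nothing available here explains the size of the methyl step.

The compounds shown leave open whether an ethyl group or a second methyl on the same carbon would lower the number further, or whether the gain stops at a single methyl. They also leave open how a longer chain between the ring nitrogen and the carboxylic acid would read, and whether an amide or a tetrazole could take the place of that acid.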